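This account rests on a few compounds, and the source may have more. Where it says the series, first, only, none or still open, it means among the compounds named here.

Measured compounds:
compound 1 `O=C(Nc1ccccc1C(F)(F)F)C1CCc2ccccc2N1`: 53300 nM
compound 2 `CCC(=O)N1c2ccccc2CCC1C(=O)Nc1ccccc1C(F)(F)F`: a limit, > 80000 nM
compound 3 `CCC(=O)N1c2ccccc2CCC1C(=O)Nc1cc(C(F)(F)F)cc(C(F)(F)F)c1`: 8540 nM

In a functional assay on PC-3 cells (Homo sapiens) for cytotoxicity, read by sulforhodamine B assay, with a stated time of 72 h (on this read-out lower numbers stand for stronger inhibition of growth and higher numbers for weaker inhibition of growth), compound 1 gives 53300 nM. For compound 2 this assay reports only a limit, > 80000 nM, not a number. Compound 3 gives 8540 nM in this assay, the lower of the two numbers. Among the compounds with values here, the one measured step, an at least 1.5-fold lower number from compound 2 to compound 1 (0.17 log units; that floor lies within the scatter), is hydrogen in place of propanoyl on a nitrogen on an aromatic ring in a ring; it has only a floor because of the limit of > 80000 nM in this assay, at which 1 of the 3 values shown sits. How the core of compound 2 differs from that of compound 3 is not broken down here. Compound 4 `O=C(Nc1cc(C(F)(F)F)cc(C(F)(F)F)c1)C1CCc2ccccc2N1` is not yet measured; it differs from compound 3 by hydrogen in place of propanoyl on a nitrogen on an aromatic ring in a ring, the same change made from compound 2 to compound 1. Compound 4 is expected to give about 5000 nM in this assay, with a likely range from 1500 nM to 20000 nM. That expected step, a 1.7-fold lower number from compound 3 to compound 4 (0.23 log units; within the scatter), rests on an at least 1.5-fold lower number from compound 2 to compound 1 (0.17 log units; that floor lies within the scatter), whose floor lies within the scatter.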

Compound 4, concentration for 50% growth inhibition: 8120 nM
For compound 4 the middle estimate is 1.6-fold (0.21 log units) below the measured one; the measured number falls inside the stated range.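

In this assay, hydrogen in place of propanoyl on the ring nitrogen gives a 1.1-fold lower number from compound 3 to compound 4 (0.02 log units; within the scatter), so on this core the two compounds cannot be told apart. Set beside the earlier pair, the comparison reads: the same change on two cores in this assay, an at least 1.5-fold lower number (0.17 log units; that floor lies within the scatter) from compound 2 to compound 1 and a 1.1-fold lower number (0.02 log units; within the scatter) from compound 3 to compound 4; the limit leaves it open whether they differ. Compound 2 carries only a limit, so this shows that neither core has a step printed beyond the scatter, but not that the change carries over with the same size.

Only propanoyl and hydrogen appear on that nitrogen, so the compounds shown leave open how an acetyl, a longer acyl chain or a carboxylic acid there would read. They also leave open whether the change behaves alike with a nitrile in place of trifluoromethyl.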